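Shortening the Benzylic Arm: A Cyanobenzyl Analogue

This account rests on a few compounds, and the source may have more. Where it says the series, first, only, none or still open, it means among the compounds named here.

Measured so far:
compound 1, `COc1ccc2nccc(C3CN(C4CCN(Cc5cc6ccccc6n5C)CC4)C(=O)O3)c2c1`, 3160 nM
compound 2, `COc1ccc2nccc(C3CN(C4CCN(CCCc5ccccc5)CC4)C(=O)O3)c2c1`, 251 nM

Both compounds share a core and differ only in the group carried on a saturated chain carbon bound to an amine nitrogen in a ring. In an in vitro functional assay on RBL cells for antagonist activity at C-C chemokine receptor type 8 (Homo sapiens), read by FLIPR and calcium flux (on this read-out higher numbers stand for weaker inhibition and lower numbers for stronger inhibition), compound 2 gives 251 nM, the lowest of the two numbers, while compound 1 gives 3160 nM. The step of a 13-fold lower number from compound 1 to compound 2 (1.10 log units; beyond the scatter) is the only one measured, and it is large.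

Compound 3, `COc1ccc2nccc(C3CN(C4CCN(Cc5ccc(C#N)cc5)CC4)C(=O)O3)c2c1`, is not yet measured. The change from compound 2 to compound 3 is 4-cyanophenyl in place of phenethyl on a saturated chain carbon bound to an amine nitrogen in a ring. Within the data shown here, only the step of a 13-fold lower number from compound 1 to compound 2 (1.10 log units; beyond the scatter) bears on it, and only loosely: it shows that a benzylic heteroaryl arm gave a much higher number than the longer phenyl arm of compound 2, but nothing measured carries a 4-cyanophenyl group, nor a plain phenyl at this shorter distance. The direction toward compound 1 is therefore expected, with much uncertainty.

Compound 3 is estimated to give 1000 nM in this assay, within 250 nM to 4000 nM, a step of a 4.0-fold higher number from compound 2 to compound 3 (0.60 log units; beyond the scatter).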

Compound 3, half-maximal inhibitory concentration: 12600 nM
Estimate against measurement, compound 3: 13-fold (1.10 log units) below, outside the stated range (above it).
By their numbers in this assay, from the lowest: compound 2; then compound 1; then compound 3.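

The 3-phenylpropyl arm of compound 2 now stands apart from both arms attached through a single saturated chain carbon: in this assay, replacing phenethyl with 4-cyanophenyl at this place gives a large change (a 50-fold higher number from compound 2 to compound 3 (1.70 log units; beyond the scatter)), larger than the one that separated the first two compounds. The 4-cyanobenzyl arm also falls behind the indole-bearing arm, though more modestly (a 4.0-fold higher number from compound 1 to compound 3 (0.60 log units; beyond the scatter)), so among the three compounds shown, compound 3 is the weakest inhibitor and the shorter arm does not regain what compound 2 shows at this place. No evidence here explains the size of either step or links it to a feature of the 4-cyanophenyl group.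

The compounds shown do not separate the shorter arm from the added nitrile, since neither a plain benzyl group nor a 3-(4-cyanophenyl)propyl group appears among them at this place. Also open, from the compounds shown here alone, is how a 4-phenylbutyl chain, or a 3-phenylpropyl arm carrying a methoxy group or an amine on its phenyl ring, would read out in this same test.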